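Methyl for fluoro on the core: a second reading

The source may hold more compounds than are shown below. What is called first, only, known or untested is meant among the compounds shown, and "the series" means these compounds.

Three quinoline sulfones carrying the same methylpiperidine were studied in an assay on isolated protein for displacement of a labelled ligand from metabotropic glutamate receptor 5 (Homo sapiens), with a stated time of 60 min, tested at 1 uM; a lower number here means less inhibition, a higher number more inhibition at the concentration tested (going by the name of the read-out). Compound 1 `COc1ccc2ncc(S(=O)(=O)c3ccc(C)cc3)c(N3CCC(C)CC3)c2c1` gives 90%. Compound 2 `COc1ccc2ncc(S(=O)(=O)c3ccc(F)cc3)c(N3CCC(C)CC3)c2c1` gives 27%. Compound 3 `CC1CCN(c2c(S(=O)(=O)c3ccc(C#N)cc3)cnc3ccc(F)cc23)CC1` gives 75%. The difference between compound 2 and compound 1 is methyl in place of fluoro on an aromatic carbon, and the step it made is a number 63 percentage points higher from compound 2 to compound 1 (beyond the scatter). Compound 3 stands second of the three, and the difference between the core of compound 3 and that of compound 2 is not broken down here.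

Compound 4 `Cc1ccc2ncc(S(=O)(=O)c3ccc(C#N)cc3)c(N3CCC(C)CC3)c2c1` remains to be measured. It differs from compound 3 by methyl in place of fluoro on an aromatic carbon. Within the data shown here, this is the same kind of change as the one from compound 2 to compound 1, but not the same: there the exchanged group sat on a six-membered aromatic ring of carbon only, para to a large group, whereas here it sits on a six-membered aromatic ring of carbon only that is part of a fused system of two rings, meta to a fused ring and para to a fused ring.

The earlier exchange gave a large gain, and compound 3 already stands high, so the room left for compound 4 is limited. The step from compound 3 to compound 4 is expected to be a number 10 percentage points higher from compound 3 to compound 4 (within the scatter), resting on the gain of a number 63 percentage points higher from compound 2 to compound 1 (beyond the scatter) and on the position of compound 3 at 75%. Compound 4 is therefore estimated to give 85%, between 65% and 97%.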

Compound 4, a percentage reported as inhibition, at one concentration (the size of the read-out at that concentration, not a potency): 55%
For compound 4 the middle estimate is 30 percentage points above the measured one; measured number outside the range, below it.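

In this assay the exchange of fluoro for methyl on an aromatic carbon of the fused system of two rings gave a number 20 percentage points lower from compound 3 to compound 4 (beyond the scatter), the opposite direction to the earlier exchange on the ring outside that system, so the gain seen there did not carry over to this place: the same change on two cores in this assay, a number 63 percentage points higher (beyond the scatter) from compound 2 to compound 1 and a number 20 percentage points lower (beyond the scatter) from compound 3 to compound 4, 83 percentage points apart, beyond the scatter of two such steps. This shows that, within this series, the sign of the step cannot be taken from one pair of compounds to another, even where the atoms exchanged are the same. It does not show what lies behind the reversal, since the two pairs differ in the place of the exchange and also in the rest of the structure, with a methoxy group on the core in one pair and a nitrile on the sulfone's aryl ring in the other, and two pairs cannot separate these differences or establish a rule.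

The compounds shown leave open how chloro, an amine or a plain hydrogen at that aromatic carbon would read in this assay, and whether the same reversal would hold with a morpholine in place of the methylpiperidine. They also leave open how these steps would look as potencies, as each reading comes from a single concentration.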